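The source may report more compounds than this note shows. Statements on the series, on what has been measured and on what is new or still open speak of the compounds shown alone.

Compound 1, `CC[C@@H]1C(=O)N(C)c2cnc(-n3ccc4cc(C(=O)NC(C)C)ccc43)nc2N1C1CCCC1`; in a functional assay on NCI-H1975 cells (Homo sapiens) for antiproliferative activity, read by CCK-8 assay, with a stated time of 72 h (on this read-out lower numbers stand for stronger inhibition of growth and higher numbers for weaker inhibition of growth), compound 1 gives 1840 nM.
Compound 2, `CC[C@@H]1C(=O)N(C)c2cnc(-n3ccc4cc(C(=O)NC5CCCC5)ccc43)nc2N1C1CCCC1`; in this assay compound 2 gives 856 nM.
Compound 3, `CC[C@@H]1C(=O)N(C)c2cnc(-n3ccc4cc(C(=O)NC)ccc43)nc2N1C1CCCC1`; in this assay compound 3 gives 1370 nM.

All three share one core and differ only in the group carried on the amide-type nitrogen. Compound 3, with the smallest of these groups, stands second highest of the three numbers, but the step of a 1.3-fold lower number from compound 1 to compound 3 (0.13 log units; within the scatter) and the step of a 1.6-fold higher number from compound 2 to compound 3 (0.20 log units; within the scatter) both lie within the scatter, so no order among them can be read from the data.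

Compound 4, `CCCNC(=O)c1ccc2c(ccn2-c2ncc3c(n2)N(C2CCCC2)[C@H](CC)C(=O)N3C)c1`, differs from compound 3 by ethyl in place of hydrogen on a saturated chain carbon bound to an amide-type nitrogen. Going by the values given here, the one change at this position that went beyond the scatter was a 2.1-fold lower number from compound 1 to compound 2 (0.33 log units; beyond the scatter), a modest step; the others were within it. A propyl group sits between methyl and cyclopentyl in the count of carbons, so at most a small move toward a lower number is expected, and a step within the scatter is just as likely. The expected step is a 1.4-fold lower number from compound 3 to compound 4 (0.14 log units; within the scatter). Compound 4 is therefore estimated at 1000 nM, in the range 500 nM to 2200 nM.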

Compound 4, concentration for 50% growth inhibition: 786 nM
The estimate for compound 4 lay 1.3-fold (0.10 log units) above the measured number; the measured number falls inside the stated range.
By their numbers in this assay, from the lowest: compounds 4, 2, 3 and 1 (each within the scatter of the next, the first and the last beyond it).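

In this assay the propyl group gives the second step beyond the scatter at this position, a 2.3-fold lower number from compound 1 to compound 4 (0.37 log units; beyond the scatter) and, like the first, this step is modest and starts from the isopropyl group. Against the other two groups nothing separates: a 1.7-fold lower number from compound 3 to compound 4 (0.24 log units; within the scatter) and a 1.1-fold lower number from compound 2 to compound 4 (0.04 log units; within the scatter) both lie within the scatter, so methyl, propyl and cyclopentyl cannot be ranked. Compound 1 is set apart only from compound 2 and compound 4, not from compound 3, so the number does not follow the size of the group in any simple way across these four compounds.

Still open, going by these compounds, is how a longer chain such as butyl, or a chain carrying an amine or a carboxylic acid, would read at this position. No measurement at hand explains why compound 1 stands apart from compound 2 and compound 4.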